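Methoxy additions on the aryl ring of the series

The compounds below may be only part of what the source reports. "The series", "measured", "known", "first", "only" and "open" are said of these compounds alone.

The series shares one core, carried by compound 1 `CCOC(=O)[C@@H]1CC(=O)c2sccc2[C@H]1c1ccc(OC)cc1`, compound 2 `CCOC(=O)[C@@H]1CC(=O)c2sccc2[C@H]1c1ccc(OC)c(OC)c1` and compound 3 `CCOC(=O)[C@@H]1CC(=O)c2sccc2[C@H]1c1ccccc1OC`. In a physicochemical assay, with a stated time of 60 min, tested at 20 ug/mL (on this read-out lower numbers stand for a weaker effect and higher numbers for a stronger effect at the one concentration tested), compound 1 gives 13%. In this assay, going by the values given here, compound 2 gives 12.2%, and the one step between them, methoxy in place of hydrogen on an aromatic carbon, is a number 0.8 percentage points lower from compound 1 to compound 2 (within the scatter). In this assay, among the compounds with values here, compound 3 gives 11.9%, a number within the scatter of both compound 2 and compound 1; no step is computed between compound 3 and either of them, so only the values themselves are compared.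

Compound 4 `CCOC(=O)[C@@H]1CC(=O)c2sccc2[C@H]1c1ccc(OC)cc1OC` differs from compound 3 by methoxy in place of hydrogen on an aromatic carbon. Within the data shown here, the only measured step of the same kind is the one from compound 1 to compound 2, and it lay within the scatter. On that basis no step beyond the scatter is expected for compound 4 in this assay, and the expected change is a number 0.1 percentage points higher from compound 3 to compound 4 (within the scatter). Compound 4 is therefore estimated at 12% in this assay, with a range from 4% to 22%.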

Compound 4, a percentage reported as activity, at one concentration (the size of the read-out at that concentration, not a potency): 10.1%
Beside the measured number, compound 4's estimate is 1.9 percentage points above it; low and high end bracket the measured number.
By their numbers in this assay, from the lowest: compounds 4, 3, 2 and 1 (each within the scatter of the next).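

In this assay, methoxy in place of hydrogen on an aromatic carbon, here meta to a methoxy group and para to a large group, is a number 1.8 percentage points lower from compound 3 to compound 4 (within the scatter) and so adds a second example of this change that stays inside the noise of the read-out. Compound 4 can also be reached from compound 1 by methoxy in place of hydrogen at a different aromatic carbon, and that change is a number 2.9 percentage points lower from compound 1 to compound 4 (within the scatter) as well, so all three methoxy steps now available on this ring, counting the earlier one from compound 1 to compound 2, lie within the scatter and none of the places tried separates from the others. Nothing measured alongside these numbers speaks to why the read-out stays this close across the series.

On these data alone, whether a group other than methoxy at this place, such as an amine, a carboxylic acid or a longer alkoxy chain, would give a step beyond the scatter remains open. Also open, as far as these compounds go, is whether changes away from the aryl ring, for instance an amide in place of the ethyl ester, would move this assay at all.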